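Thiophene substituent change and rat microsomal half-life

A few compounds are considered here, and "the series" means these few. Any claim that something is new, unique, unknown or untested is made for them only; others in the source may bear on it.

Measured so far in an ADME assay on microsomes from liver (Rattus norvegicus) for metabolic stability; on this read-out lower numbers stand for a shorter-lived compound and higher numbers for a longer-lived compound:
- compound 1 `CC#C[C@@H](Cc1nnn[nH]1)c1ccc(OCc2cc(F)c3scc(-c4ccc(OC)cc4C)c3c2)cc1`: 0.333 h
- compound 2 `CC#C[C@@H](Cc1nnn[nH]1)c1ccc(OCc2ccc3scc(-c4ccc(OCCC(C)(C)O)cc4C)c3c2)cc1`: 1.03 h
- compound 3 `CC#C[C@@H](Cc1nnn[nH]1)c1ccc(OCc2ccc3sc(C#N)c(-c4ccccc4C)c3c2)cc1`: 0.533 h

Compound 3 falls between the other two on this read-out, yet its gap to compound 1 and its gap to compound 2 both lie within the usual scatter, so the three numbers give no reliable order.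

Compound 4 `CC#C[C@@H](Cc1nnn[nH]1)c1ccc(OCc2ccc3sc(I)c(-c4ccccc4C)c3c2)cc1` differs from compound 3 in one place: iodo in place of cyano on an aromatic carbon. Among the measured compounds shown here, no measured pair in the set carries this change, so there is no step to lean on. The expected step is a 1.2-fold lower number from compound 3 to compound 4 (0.07 log units; within the scatter), not beyond the scatter. Compound 4 is accordingly estimated at 0.45 h, with the expected range running from 0.2 h to 1 h.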

Compound 4, half-life: 0.483 h
Compound 4: middle estimate off by 1.1-fold (0.03 log units), on the low side; the measured number falls inside the stated range.
By their numbers in this assay, from the lowest: compounds 1, 4, 3 and 2 (each within the scatter of the next, the first and the last beyond it).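

Iodo in place of cyano, on the aromatic carbon next to the ring sulfur, gives the first comparison in the series that differs in one place. In this assay this swap gives a 1.1-fold lower number from compound 3 to compound 4 (0.04 log units; within the scatter) and so does not separate the two groups, although a triple bond and a hydrogen-bond acceptor leave. Nothing at hand explains this result.

On these data alone, whether an amine or a carboxylic acid on this carbon would separate from cyano and iodo stays open. Also open, as far as these compounds go, is whether the swap reads the same with another group in place of the 2-methylphenyl group.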